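This account rests on a few compounds, and the source may have more. Where it says the series, first, only, none or still open, it means among the compounds named here.

Measured compounds:
compound 1, `O=C1c2c[n+]([O-])c3ccccc3c2C(=O)c2c1c1ccccc1n2Cc1cn([C@H]2C[C@H](O)[C@@H](CO)O2)nn1`, 390 nM
compound 2, `O=C1c2c[n+]([O-])c3ccccc3c2C(=O)c2c1c1ccccc1n2Cc1cn([C@@H]2C[C@H](O)[C@@H](CO)O2)nn1`, 20 nM
compound 3, `CC1(C)OC[C@H](Cn2cc(Cn3c4c(c5ccccc53)C(=O)c3c[n+]([O-])c5ccccc5c3C4=O)nn2)O1`, 180 nM

In a functional assay on A-375 cells (Homo sapiens) for cytotoxicity, read by MTT assay, with a stated time of 72 h (on this read-out lower numbers stand for stronger inhibition and higher numbers for weaker inhibition), compound 3 stands second highest of the three numbers. Its nearest neighbour is compound 1, a 2.2-fold lower number from compound 1 to compound 3 (0.34 log units; beyond the scatter); its furthest is compound 2, a 9.0-fold higher number from compound 2 to compound 3 (0.95 log units; beyond the scatter). The two compounds bearing the 4-hydroxy-5-(hydroxymethyl)oxolan-2-yl group differ only in configuration as drawn, yet a 20-fold lower number from compound 1 to compound 2 (1.29 log units; beyond the scatter) (the fact that compounds 1 and 2 differ only in the configuration as drawn).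

Compound 4, `O=C1c2c[n+]([O-])c3ccccc3c2C(=O)c2c1c1ccccc1n2Cc1cn([C@@H]2O[C@H](CO)[C@@H](O)[C@H](O)[C@H]2O)nn1`, is not yet measured. It differs from compound 3 in one place: 3,4,5-trihydroxy-6-(hydroxymethyl)oxan-2-yl in place of (2,2-dimethyl-1,3-dioxolan-4-yl)methyl on an aromatic nitrogen. Going by the values given here, the steps that bear on this change are those in which the (2,2-dimethyl-1,3-dioxolan-4-yl)methyl group of compound 3 is exchanged for a ring on the same aromatic nitrogen: a 2.2-fold lower number from compound 1 to compound 3 (0.34 log units; beyond the scatter) and a 9.0-fold higher number from compound 2 to compound 3 (0.95 log units; beyond the scatter). Both point the same way, the compound carrying the (2,2-dimethyl-1,3-dioxolan-4-yl)methyl group giving the higher number, though the gap between the two steps is wide. A lower number than compound 3 is therefore expected for compound 4, of modest size, a 2.3-fold lower number from compound 3 to compound 4 (0.35 log units; beyond the scatter). The estimate for compound 4 is 80 nM, with a range from 25 nM to 300 nM.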

Compound 4, half-maximal inhibitory concentration: 230 nM
Beside the measured number, compound 4's estimate is 2.9-fold (0.46 log units) below it; the measured number falls inside the stated range.
By their numbers in this assay, from the lowest: compound 2; then compounds 3, 4 and 1 (each within the scatter of the next, the first and the last beyond it).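

Exchanging (2,2-dimethyl-1,3-dioxolan-4-yl)methyl for 3,4,5-trihydroxy-6-(hydroxymethyl)oxan-2-yl on the aromatic nitrogen gives no resolved difference in this assay, although the two groups differ in ring size and hydrogen-bond donors: a 1.3-fold higher number from compound 3 to compound 4 (0.11 log units; within the scatter). Against the 4-hydroxy-5-(hydroxymethyl)oxolan-2-yl pair, the same group gives two different readings: a 1.7-fold lower number from compound 1 to compound 4 (0.23 log units; within the scatter), but a 12-fold higher number from compound 2 to compound 4 (1.06 log units; beyond the scatter). A hydroxylated ring on this nitrogen therefore does not by itself reproduce the low number of compound 2, which stays tied to one drawn arrangement, the relevant contrast being: the fact that compounds 1 and 2 differ only in the configuration as drawn.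

Compound 4 appears in one drawn configuration only, leaving open whether configuration at its oxan-2-yl attachment carbon matters here. Also open is how an amine or a carboxylic acid on a longer chain at this aromatic nitrogen would compare with the ring groups shown.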